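The source may hold more compounds than are shown below. What is called first, only, known or untested is meant among the compounds shown, and "the series" means these compounds.

Measured in a functional assay on microsomes for inhibition, with a stated time of 1 h; a lower number here means a stronger inhibitor, a higher number a weaker inhibitor:
Compound 1 `COc1ccc(-c2nc(SC)n(C)c(=O)c2C#N)cc1`: 53 ug/mL
Compound 2 `CN(C)c1ccc(-c2nc(NN)n(C)c(=O)c2C#N)cc1`: 63 ug/mL

Only these two numbers are available, and they lie within the usual scatter of repeated measurements. Compound 2 at 63 ug/mL therefore cannot be told apart from compound 1 in this assay.

Compound 3 `CSc1nc(-c2ccc(N(C)C)cc2)c(C#N)c(=O)n1C` has not yet been measured. It is compound 2 with methylsulfanyl in place of aminoamino on an aromatic carbon, (methylsulfanyl in place of aminoamino on an aromatic carbon). This carbon sits between two ring nitrogen atoms, para to a cyano group.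

For the measured compounds named here, no pair of measured compounds differs in a single place, so no measured step shows what this swap does. The nearest guide is compound 1, which already carries methylsulfanyl at this place and gives 53 ug/mL, although it also differs from compound 3 elsewhere. Going by the values given here, that value lies close to the one for compound 2, so no shift beyond the scatter is expected in this assay. The estimated change is a 1.1-fold lower number from compound 2 to compound 3 (0.06 log units; within the scatter). For compound 3 the expected value is 55 ug/mL, with an estimated range of 25 ug/mL to 120 ug/mL.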

Compound 3, half-maximal inhibitory concentration: 98 ug/mL
Beside the measured number, compound 3's estimate is 1.8-fold (0.25 log units) below it; the measured number falls inside the stated range.
By their numbers in this assay, from the lowest: compounds 1, 2 and 3 (each within the scatter of the next).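

In this assay, for the compounds shown here, swapping aminoamino, with its 2 hydrogen-bond donors, for methylsulfanyl, with none, on the carbon between two ring nitrogen atoms gives a 1.6-fold higher number from compound 2 to compound 3 (0.19 log units; within the scatter) and so has a measured step for the first time; this difference in donor count comes with no change that can be told from the scatter. Compound 3 also provides a single-place comparison at the other end of the molecule, where dimethylamino in place of methoxy on an aromatic carbon gives a 1.8-fold higher number from compound 1 to compound 3 (0.27 log units; within the scatter), again with no separable change. No other measurement bears on why these steps are so small.

All the compounds shown carry either aminoamino or methylsulfanyl at the carbon between two ring nitrogen atoms, so it remains open whether a different group there, such as a simple amine, a longer sulfur-linked chain or a carboxylic acid, would shift the number beyond the scatter. At the other changed place only methoxy and dimethylamino appear, which leaves open what a chlorine atom or a plain hydrogen would do.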